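A few compounds are considered here, and "the series" means these few. Any claim that something is new, unique, unknown or untested is made for them only; others in the source may bear on it.

Measured so far in a functional assay on VCaP cells (Homo sapiens) for antiproliferative activity, read by CCK-8 assay, with a stated time of 6 days; on this read-out higher numbers stand for weaker inhibition and lower numbers for stronger inhibition:
- compound 1 `CC(O)c1ccc(C(=O)N[C@@H](C)Cn2ccc(-c3ccc(C#N)c(Cl)c3)n2)cc1`: 910 nM
- compound 2 `C[C@@H](Cn1ccc(-c2ccc(C#N)c(Cl)c2)n1)NC(=O)C1CC(=O)C1`: 22500 nM

Of these two numbers, compound 2 has the higher, at 22500 nM. Compound 3 `C[C@@H](Cn1ccc(-c2ccc(C#N)c(Cl)c2)n1)Nc1ncccn1` is next, with this change: pyrimidin-2-yl in place of (3-oxocyclobutyl)carbonyl on an amine nitrogen. Among the compounds with values here, only one measured step bears on it: a 25-fold higher number from compound 1 to compound 2 (1.39 log units; beyond the scatter), a large step. Within the data shown here, that step kept the carbonyl, so it is only a partial guide, and no measured compound lacks the carbonyl. A moderate move toward lower numbers in this assay is expected, with the aromatic ring returning: a 4.5-fold lower number from compound 2 to compound 3 (0.65 log units; beyond the scatter). For compound 3 the estimated value is 5000 nM, with an expected range of 1200 nM to 20000 nM.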

Compound 3, half-maximal inhibitory concentration: 480 nM
The estimate for compound 3 lay 10-fold (1.02 log units) above the measured number; measured number below the stated range.
By their numbers in this assay, from the lowest: compounds 3 and 1 (each within the scatter of the next); then compound 2.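

In this assay, pyrimidin-2-yl in place of (3-oxocyclobutyl)carbonyl on an amine nitrogen gives a 47-fold lower number from compound 2 to compound 3 (1.67 log units; beyond the scatter), so a low number at this position does not depend on a carbonyl. Compound 3, without that carbonyl, and compound 1, with it, lie within the usual scatter of each other. No measured property accounts for this step.

Open, going by these compounds, is whether the ring nitrogens of pyrimidin-2-yl matter, a question that a phenyl or pyridin-2-yl group on the same amine nitrogen would address.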